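Ethyl in place of methyl on a shared uracil-type core

The source may hold more compounds than are shown below. What is called first, only, known or untested is meant among the compounds shown, and "the series" means these compounds.

Compound 3 `Cc1cn(COC(CO)CO)c(=O)[nH]c1=O` was tested in a functional assay on Vero cells (Chlorocebus sabaeus) for cytotoxicity; a lower number here means that less compound is tolerated, a higher number that more compound is tolerated. In this assay compound 3 gives only > 434000 nM, which is a limit of the assay and not a number. Compound 1 `O=c1[nH]c(=O)n(COC(CO)CO)cc1[N+](=O)[O-]` likewise gives only the limit > 383000 nM. Compound 2 `Nc1cn(COC(CO)CO)c(=O)[nH]c1=O` also gives only the limit > 432000 nM. Because all three values sit at limits the limit of > 383000 nM in this assay, at which 1 of the 3 values shown sits, the limit of > 432000 nM in this assay, at which 1 of the 3 values shown sits (the limit of > 434000 nM in this assay, at which 1 of the 3 values shown sits), the steps a step that the two limits leave unreadable from compound 1 to compound 2, a step that the two limits leave unreadable from compound 1 to compound 3 and a step that the two limits leave unreadable from compound 2 to compound 3 cannot be read in size or direction. Compound 4 `CCc1cn(COC(CO)CO)c(=O)[nH]c1=O` differs from compound 3 by methyl in place of hydrogen on a saturated chain carbon bound to an aromatic carbon. Within the data shown here, no measured step bears on such a change, and the three limits offer no direction. Compound 4 is therefore expected to sit at a limit as well, estimated at 450000 nM with a range from 200000 nM to 1500000 nM. This amounts to an expected step that the limit leaves unreadable from compound 3 to compound 4, none beyond the scatter.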

Compound 4, half-maximal cytotoxic concentration: > 410000 nM
Compound 4: a limit, no number; the forecaster's own chance of this, stated with the estimate: 85%; the middle value is on the limit's open side.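

Among these compounds, compound 4 gives only a limit, as do compounds 1, 2 and 3, and no step to compound 4 can be read in size or direction. On these data alone, whether nitro, amino, methyl or ethyl on the shared core makes any difference in this assay stays open.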